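Piperidinyl-ethyl ether restored on the phenol of compound 2

A few compounds are considered here, and "the series" means these few. Any claim that something is new, unique, unknown or untested is made for them only; others in the source may bear on it.

Going by the values given here, compound 2 `Oc1cccc2c1nc(COc1ccc(Cl)cc1)n2CCCC1CCCNC1` is the weaker of the two measured members: in an assay on isolated protein for binding affinity to Neuropeptide Y receptor type 1 (Homo sapiens) (on this read-out lower numbers stand for stronger inhibition and higher numbers for weaker inhibition), compound 2 gives 5300 nM, the highest number of the two. Among the compounds with values here, its only neighbour, compound 1 `Clc1ccc(OCc2nc3c(OCCC4CCNCC4)cccc3n2CCCC2CCCNC2)cc1`, carries 2-(piperidin-4-yl)ethyl on that oxygen and gives 7 nM in this assay; the single measured step, a 760-fold higher number from compound 1 to compound 2 (2.88 log units; beyond the scatter), shows how much the bare hydroxy costs. Compound 3 `Clc1ccc(OCc2nc3c(OCCC4CCCNC4)cccc3n2CCCC2CCCNC2)cc1` reinstates an ether of closely related shape: the change is 2-(piperidin-3-yl)ethyl in place of hydrogen on an oxygen on an aromatic ring. Within the data shown here, no measured pair isolates the shift of the ring nitrogen from the 4- to the 3-position, so the only bearing step is the one from compound 1 to compound 2, taken in reverse; the expectation is therefore a large fall in this assay, possibly not the whole way back. Compound 3 is estimated at 15 nM in this assay, range 4 nM to 60 nM, which means an expected step of a 350-fold lower number from compound 2 to compound 3 (2.55 log units; beyond the scatter).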

Compound 3, inhibition constant: 18 nM
Beside the measured number, compound 3's estimate is 1.2-fold (0.08 log units) below it, and the stated range covers the measured number.
By their numbers in this assay, from the lowest: compound 1; then compound 3; then compound 2.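

In this assay, the large recovery seen on restoring an ether at this oxygen does not depend on the exact piperidin-4-yl arrangement of compound 1: 2-(piperidin-3-yl)ethyl in place of hydrogen gives a 290-fold lower number from compound 2 to compound 3 (2.47 log units; beyond the scatter). The placement of the ring attachment still registers, though on a much smaller scale, since piperidin-3-yl in place of piperidin-4-yl gives a 2.6-fold higher number from compound 1 to compound 3 (0.41 log units; beyond the scatter). So this position tolerates a shift within the piperidine ring at a modest cost, while the bare hydroxy of compound 2 remains far behind both ethers; no supporting data bear on the origin of either step.

Still open, going by these compounds, is whether the ring nitrogen is needed at all, which a cyclohexyl ring on the same ethoxy chain, or a methyl group on that nitrogen, would address. The length of the link is equally unsettled, as the compounds shown offer no propyl chain or single methylene in place of the ethyl chain, and no piperidin-2-yl isomer to complete the comparison in this assay.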